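The compounds below may be only part of what the source reports. "The series", "measured", "known", "first", "only" and "open" are said of these compounds alone.

Measured in a functional assay on HFF cells (Homo sapiens) for cytotoxicity; on this read-out higher numbers stand for weaker inhibition and lower numbers for stronger inhibition:
- compound 1 `COC[C@H]1OC(n2c(Cl)nc3cc(Cl)c(Cl)cc32)[C@H](O)[C@@H]1O`: 32000 nM
- compound 2 `O[C@@H]1[C@@H](CCl)OC(n2c(Cl)nc3cc(Cl)c(Cl)cc32)[C@@H]1O`: 32000 nM

Among the compounds with values here, compound 1 stands level with compound 2 at 32000 nM, and no other measured compound lies nearer to compound 2.

The open question is compound 3 `O[C@@H]1[C@@H](CBr)OC(n2c(Cl)nc3cc(Cl)c(Cl)cc32)[C@@H]1O`, which differs from compound 2 in one group: bromo in place of chloro on a saturated chain carbon bound to a saturated ring carbon. In words, this is bromo in place of chloro on a saturated chain carbon bound to a saturated ring carbon.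

Within the data shown here, only one measured step bears on this change, and it falls at the same place: no change at the digits printed from compound 1 to compound 2 (within the scatter). Among the measured compounds shown here, it exchanged methoxy for chloro, so it is only indirect support, and no bromo compound has been measured yet.

In this assay, no step beyond the scatter is expected, so the expected step is no change at the digits printed from compound 2 to compound 3 (within the scatter). The estimate for compound 3 is 32000 nM, with an estimated range of 13000 nM to 75000 nM.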

Compound 3, half-maximal inhibitory concentration: 32000 nM
Estimate against measurement, compound 3: no gap at the digits printed; the measured number falls inside the stated range.
By their numbers in this assay, from the lowest: compounds 1, 2 and 3 (each within the scatter of the next).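

In this assay, the exchange between the two halogens now has a direct reading at this position: the step runs no change at the digits printed from compound 2 to compound 3 (within the scatter), whereas the earlier pair covered only methoxy and chloro. Bromo in place of methoxy at the same place gives no change at the digits printed from compound 1 to compound 3 (within the scatter), so methoxy, chloro and bromo on a saturated chain carbon bound to a saturated ring carbon all read alike across these three compounds, which share the same core. No supporting evidence bears on this result.

On these data alone, whether this position stays as insensitive with an amine, a carboxylic acid or a longer chain in place of these groups remains open. Also open, as far as these compounds go, is whether the sameness among methoxy, chloro and bromo holds on any core other than the shared one.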